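The compounds below may be only part of what the source reports. "The series", "measured", "known", "first", "only" and "open" are said of these compounds alone.

Measured so far:
compound 1 `COc1cccc(/C=C/C(=O)c2c(OC)cc(OC)cc2OC)c1` — 0%
compound 2 `COc1cc(OC)c(C(=O)/C=C/c2ccc(Cl)cc2)c(OC)c1` — 0%

Both numbers come from a functional assay on HaCaT cells (Homo sapiens), read by fluorescence and BrdU incorporation, with a stated time of 48 h, tested at 25 uM; on this read-out higher numbers stand for a weaker effect at the one concentration tested and lower numbers for a stronger effect. Compound 2 stands level with compound 1 at the value shown: the step of no change at the digits printed from compound 1 to compound 2 (within the scatter) lies within the scatter, so the two aryl groups on the double-bonded chain carbon gave the same reading at the one concentration tested.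

The next compound is compound 3 `COc1cc(OC)c(C(=O)/C=C/c2ccc(Br)cc2)c(OC)c1`. It differs from compound 2 by bromo in place of chloro on an aromatic carbon.

Within the data shown here, only one measured step bears on this change, no change at the digits printed from compound 1 to compound 2 (within the scatter), and it was flat; a larger swap of the aryl group than the one from compound 2 to compound 3 left the read-out at the same level. For the halogen exchange the step from compound 2 to compound 3 is expected to be no change at the digits printed from compound 2 to compound 3 (within the scatter), no change beyond the scatter. Compound 3 is therefore estimated at 0%, with an expected range from 0% to 12%.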

Compound 3, a percentage reported as activity, at one concentration (the size of the read-out at that concentration, not a potency): 0.3%
For compound 3 the middle estimate is 0.3 percentage points below the measured one; the measured number falls inside the stated range.
By their numbers in this assay, from the lowest: compounds 1, 2 and 3 (each within the scatter of the next).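

At the aromatic carbon para to a large group, the halogen exchange now has a direct reading in this assay: a number 0.3 percentage points higher from compound 2 to compound 3 (within the scatter), so chloro and bromo cannot be told apart at the one concentration tested. The wider swap of aryl groups gives the same picture, with a number 0.3 percentage points higher from compound 1 to compound 3 (within the scatter), so 4-bromophenyl joins 3-methoxyphenyl and 4-chlorophenyl at one level, on the strong-effect side of the read-out. Nothing available accounts for this flat result.

From the compounds shown here alone, whether an amine or a carboxylic acid in place of the halogen would carry the number beyond the scatter remains open. Going by these compounds, with all three compounds this close at a single concentration, it also remains open whether a full concentration series would separate them.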